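This account rests on a few compounds, and the source may have more. Where it says the series, first, only, none or still open, it means among the compounds named here.

Measured compounds:
compound 1, `CC(=O)O[C@@H]1OC(=O)[C@](C)(C(C)=O)[C@@H]1C`, 5000 nM in a functional assay on HT-29 cells (Homo sapiens) for cytotoxicity, read by MTT assay; on this read-out lower numbers stand for stronger inhibition and higher numbers for weaker inhibition
compound 2, `CC(=O)[C@@]1(C)C(=O)O[C@@H](OC(=O)c2ccccc2)[C@H]1C`, 1000 nM
compound 3, `CC(=O)O[C@@H]1OC(=O)[C@@](C)(C(C)=O)[C@@H]1C`, 12000 nM

Compound 4, `CC(=O)O[C@@H]1OC(=O)[C@@](C)(C(=O)c2ccccc2)[C@@H]1C`, has not yet been measured in this assay.

Compounds 1 and 3 share every atom and bond and differ only in configuration: the two compounds have the same atoms and bonds and differ only in configuration as drawn: 1 of 3 stereo elements differ; a stereocentre at a saturated ring carbon is drawn S in compound 1 and R in compound 3. The step of a 2.4-fold higher number from compound 1 to compound 3 (0.38 log units; beyond the scatter) shows compound 3 giving the highest number of the three, and it rests on the fact that (the fact that compounds 1 and 3 differ only in the configuration as drawn).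

Within the compound 1 core, the change phenyl in place of methyl on a carbonyl carbon produced the step of a 5.0-fold lower number from compound 1 to compound 2 (0.70 log units; beyond the scatter). The change from compound 3 to compound 4, (phenyl in place of methyl on a carbonyl carbon), is the same kind of change, but the place is not the same: in the earlier pair the carbonyl carbon has an oxygen next to a carbonyl group as its other neighbour, whereas in compound 4 the carbonyl carbon has a saturated ring carbon as its other neighbour. On a different carbonyl and in the compound 3 core, the step is expected to be smaller than the earlier one; compound 4 is expected to show a step of a 2.4-fold lower number from compound 3 to compound 4 (0.38 log units; beyond the scatter) in this assay. The estimate for compound 4 is therefore 5000 nM, between 1500 nM and 20000 nM.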

Compound 4, half-maximal inhibitory concentration: 7000 nM
Estimate against measurement, compound 4: 1.4-fold (0.15 log units) below, and the stated range covers the measured number.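

In this assay, phenyl in place of methyl on a carbonyl carbon whose other neighbour is a saturated ring carbon gave a 1.7-fold lower number from compound 3 to compound 4 (0.23 log units; within the scatter) and this step lies within the usual scatter. Set beside the earlier step, the change did not carry over at the same size: the same change on two cores in this assay, a 5.0-fold lower number (0.70 log units; beyond the scatter) from compound 1 to compound 2 and a 1.7-fold lower number (0.23 log units; within the scatter) from compound 3 to compound 4, 2.9-fold (0.46 log units) apart, beyond the scatter of two such steps. The data do not show what separates the two steps: the pairs differ at once in the configuration of the core and in which carbonyl carbon takes the phenyl, and each case rests on a single pair.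

The compounds shown leave open how phenyl on this same carbonyl carbon would read in the core of compound 1, and how phenyl on the other carbonyl carbon would read in the core of compound 3, either of which would pull the two differences apart. Also open, on these data alone, is whether a longer chain or an amine in place of the methyl would follow either step.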